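The source may report more compounds than this note shows. Statements on the series, on what has been measured and on what is new or still open speak of the compounds shown alone.

Compound 2 `CC(=O)Oc1cccc2cc(-c3cc(Br)cs3)c(=O)oc12` is the point of departure. In a functional assay on isolated protein for antagonist activity at adenosine receptor A2b (Homo sapiens) (a higher number here means a weaker inhibitor, a lower number a stronger inhibitor), compound 2 gives > 30000 nM, which is a limit of the assay and not a number. Compound 1 `CC(=O)Oc1cccc2cc(-c3ccsc3)c(=O)oc12` differs from it at one place; in this assay compound 1 gives > 30000 nM, likewise only a limit. Compound 3 `CC(=O)Oc1ccc2cc(-c3cc(Br)cs3)c(=O)oc2c1OC(C)=O` carries one extra group on the shared core; in this assay compound 3 gives > 30000 nM, again a limit. The step that the two limits leave unreadable from compound 1 to compound 2 and the step that the two limits leave unreadable from compound 2 to compound 3 thus cannot be sized, since (the limit of > 30000 nM in this assay, at which 3 of the 3 values shown sit). Compound 4 `O=c1oc2c(O)cccc2cc1-c1cc(Br)cs1` is the compound now in question: hydrogen in place of acetyl on an oxygen on an aromatic ring. Neither measured step touches this change, and neither offers a readable size, so there is no basis for expecting movement in either direction in this assay. The expected step is therefore a step that the limit leaves unreadable from compound 2 to compound 4, nothing beyond the scatter. Compound 4 is expected to come out near 40000 nM, between 10000 nM and 200000 nM, most probably again reported only as a limit.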

Compound 4, inhibition constant: > 30000 nM
Compound 4 ended at the assay's limit (the forecaster's own chance of this, stated with the estimate: 80%); the middle value lies beyond the limit too.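

In this assay compound 4 gives > 30000 nM, a limit of the assay and not a number. Its step from compound 2 therefore cannot be read: the limit of > 30000 nM in this assay, at which 4 of the 4 values shown sit.

The compounds shown leave open whether swapping acetoxy for hydroxy changes inhibition at all.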